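A few compounds are considered here, and "the series" means these few. Any claim that something is new, unique, unknown or untested is made for them only; others in the source may bear on it.

Working notes on the series, read in an ADME assay on MT4 cells (Homo sapiens) for cytotoxicity, read by MTT assay, with a stated time of 5 days; a lower number here means that less compound is tolerated, a higher number that more compound is tolerated. Compound 1 (`Cc1cc(C)cc(S(=O)(=O)c2c(C(=O)N[C@@H]3CCNC3)[nH]c3ccc(Cl)cc23)c1`) gives 37300 nM, compound 2 (`Cc1cc(C)cc(S(=O)(=O)c2c(C(=O)N[C@@H]3CCN(Cc4cccnc4)C3)[nH]c3ccc(Cl)cc23)c1`) gives 36500 nM and compound 3 (`Cc1cc(C)cc(S(=O)(=O)c2c(C(=O)N[C@H]3CCN(S(C)(=O)=O)C3)[nH]c3ccc(Cl)cc23)c1`) gives 29900 nM. Compound 3 sits within the scatter of both other compounds.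

The next compound is compound 4 (`CCS(=O)(=O)NC(=O)c1[nH]c2ccc(Cl)cc2c1S(=O)(=O)c1cc(C)cc(C)c1`). The change is ethylsulfonyl in place of 1-(methylsulfonyl)pyrrolidin-3-yl on an amide-type nitrogen, with ethylsulfonyl in place of 1-(methylsulfonyl)pyrrolidin-3-yl on an amide-type nitrogen. Going by the values given here, no measured step makes this exact exchange. The closest evidence comes from the steps that alter the group on this nitrogen, a 1.2-fold lower number from compound 1 to compound 3 (0.10 log units; within the scatter) and a 1.2-fold lower number from compound 2 to compound 3 (0.09 log units; within the scatter), together with a 1.0-fold lower number from compound 1 to compound 2 (0.01 log units; within the scatter). All three lie within the scatter. However, each of these compounds keeps the five-membered ring, which compound 4 lacks, so they bear on the change only indirectly.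

No shift beyond the scatter is expected in this assay. The expected change is a 1.0-fold higher number from compound 3 to compound 4 (0.00 log units; within the scatter). The estimate for compound 4 is 30000 nM, with an expected range of 12000 nM to 70000 nM.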

Compound 4, half-maximal cytotoxic concentration: > 283000 nM
Compound 4 was reported as a limit; the forecaster's own chance of this, stated with the estimate: 20%; middle value at least 9.4-fold (0.97 log units) from the limit.
By their numbers in this assay, from the lowest: compounds 3, 2 and 1 (each within the scatter of the next). At a limit, above all of these: compound 4.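

Changes among the groups on the amide-type nitrogen in compound 1, compound 2 and compound 3 stayed within the scatter, so this position looked indifferent in this assay. Ethylsulfonyl breaks that picture, giving an at least 9.4-fold higher number from compound 3 to compound 4 (0.97 log units; beyond the scatter) and an at least 7.7-fold higher number from compound 2 to compound 4 (0.88 log units; beyond the scatter) and also an at least 7.5-fold higher number from compound 1 to compound 4 (0.88 log units; beyond the scatter) with all three steps beyond the scatter. Compound 4 is reported only as a limit, and it is the only compound shown at that limit: the limit of > 283000 nM in this assay, at which 1 of the 4 values shown sits.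

The change removes the five-membered ring and also places a sulfonyl directly on the amide-type nitrogen, so the compounds shown do not separate these two features. On these data alone, whether a plain ethyl chain or an acetyl group on this nitrogen would behave like ethylsulfonyl or like the pyrrolidin-3-yl groups remains open.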